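Two measured quinoxaline-type dioxides and a diacetyl variant awaiting test

The source may hold more compounds than are shown below. What is called first, only, known or untested is meant among the compounds shown, and "the series" means these compounds.

Compound 1 `N#Cc1c(N)[n+]([O-])c2ccc(Cl)cc2[n+]1[O-]` and compound 2 `CNc1c(C#N)[n+]([O-])c2cc(Cl)ccc2[n+]1[O-]` share one core and differ at a single position. In a functional assay on Ehrlich cells (Mus musculus) for cytotoxicity, read by trypan blue exclusion, with a stated time of 2 h, tested at 5 ug/mL (a lower number here means a stronger effect, a higher number a weaker effect of the compound at the concentration tested), compound 1 gives 98.8%. In this assay compound 2 gives 96%. Compound 2 therefore holds the lowest of the two numbers, and its nearest neighbour is compound 1, but the gap a number 2.8 percentage points lower from compound 1 to compound 2 (within the scatter) is within the scatter, so the two cannot be told apart on these figures; both show only a small effect at the concentration used.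

Compound 3 `CC(=O)N(C(C)=O)c1c(C#N)[n+]([O-])c2cc(Cl)ccc2[n+]1[O-]` has not yet been measured. It differs from compound 2 by diacetylamino in place of methylamino on an aromatic carbon. Within the data shown here, the only measured step, a methyl in place of hydrogen on a nitrogen, stays within the scatter, so nothing here shows that a change at this carbon moves the read-out. Among the measured compounds shown here, the present change is larger, yet no step on record speaks for a shift in either direction.

For compound 3 the expected step of a number 2 percentage points lower from compound 2 to compound 3 (within the scatter) is none beyond the scatter. Compound 3 is therefore estimated at 94%, with a range from 80% to 100%.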

Compound 3, a percentage reported as activity, at one concentration (the size of the read-out at that concentration, not a potency): 99%
Compound 3: middle estimate off by 5 percentage points, on the low side; the measured number falls inside the stated range.
By their numbers in this assay, from the lowest: compounds 2, 1 and 3 (each within the scatter of the next).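

Among these compounds, until now, the only change on record at this nitrogen was a single methyl, so it was unclear whether a far larger substituent on the same aromatic carbon, ortho to a cyano group, would register at all. Diacetylamino brings 7 heavy atoms where methylamino has 2, along with 2 double bonds outside aromatic rings and no hydrogen-bond donor, yet in this assay this gives a number 3 percentage points higher from compound 2 to compound 3 (within the scatter), and the comparison with the unsubstituted amino group gives a number 0.2 percentage points higher from compound 1 to compound 3 (within the scatter), so amino, methylamino and diacetylamino cannot be told apart here at the single concentration tested. No measurement on hand offers an explanation for this flat result.

The compounds shown leave open whether any group on this carbon, such as a piperazine ring, a longer chain like butylamino or a carboxylic acid attached through an amine, would separate itself from these three in this read-out. They also leave open whether the three would still be indistinguishable at a higher concentration or over a longer exposure.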